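The source may report more compounds than this note shows. Statements on the series, on what has been measured and on what is new or still open speak of the compounds shown alone.

Measured compounds in an ADME assay on Karpas-1106P cells (Homo sapiens) for cytotoxicity; on this read-out higher numbers stand for an effect only at larger amounts of compound and lower numbers for an effect already at smaller amounts:
Compound 1 `Cc1ccc(S(=O)(=O)N[C@@H](CC(=O)NC(C)(C)C)C(=O)NCCNC(=O)c2ccccc2)cc1`: > 11100 nM, a limit
Compound 2 `Cc1ccc(S(=O)(=O)N[C@@H](CC(=O)NC(C)(C)C)C(=O)NCCNC(=O)c2ccccc2Cl)cc1`: > 11100 nM, a limit
Compound 3 `Cc1ccc(S(=O)(=O)N[C@@H](CC(=O)NC(C)(C)C)C(=O)NCCNC(=O)c2cccc(C#N)c2)cc1`: > 11100 nM, a limit

None of these compounds has yet given a number, and all share one reading, (the limit of > 11100 nM in this assay, at which 3 of the 3 values shown sit). Compound 3 stands at that reading, and its > 11100 nM is a limit. Its place relative to the other two therefore cannot be read.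

Compound 4 `Cc1ccc(S(=O)(=O)N[C@@H](CC(=O)NC(C)(C)C)C(=O)NCCNC(=O)c2cc(C)ccn2)cc1` differs from compound 3 at one place: 4-methylpyridin-2-yl in place of 3-cyanophenyl on a carbonyl carbon. In words, 4-methylpyridin-2-yl takes the place of 3-cyanophenyl on a carbonyl carbon.

The nearest measured change is a step that the two limits leave unreadable from compound 2 to compound 3, which also exchanges the group on that carbonyl carbon. The two substitutions on the aromatic ring offer no more, with a step that the two limits leave unreadable from compound 1 to compound 2 and a step that the two limits leave unreadable from compound 1 to compound 3. Going by the values given here, no measured step thus has a size that can be carried over, and none suggests a direction. In this assay, no step beyond the scatter is expected, though the data cannot exclude one. The expected result is most likely another limit, with a step that the limit leaves unreadable from compound 3 to compound 4 as the estimated step. For compound 4, the estimated value is 15000 nM, with an expected range from 7000 nM to 30000 nM.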

Compound 4, half-maximal effective concentration: > 11100 nM
Compound 4 was reported as a limit (the forecaster's own chance of this, stated with the estimate: 85%); the middle value lies beyond the limit too.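

In this assay compound 4 gives > 11100 nM, which is a limit. Going by these compounds alone, no step from compound 1, compound 2 or compound 3 to compound 4 can be read, as all four share one reading: the limit of > 11100 nM in this assay, at which 4 of the 4 values shown sit. The compounds shown leave open whether any group on that carbonyl carbon produces a measurable effect in this assay at all.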